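This account rests on a few compounds, and the source may have more. Where it says the series, first, only, none or still open, it means among the compounds named here.

Measured in a functional assay on A549 cells (Homo sapiens) for inhibition, read by sulforhodamine B assay, with a stated time of 72 h; a lower number here means a stronger inhibitor, a higher number a weaker inhibitor:
- compound 1 `Nc1sc(-c2ccc(Cl)cc2)c(-c2ccc(Cl)cc2)c1C(=O)N1CCCCC1`: 4620 nM
- compound 2 `Nc1sc(-c2ccc(Cl)cc2)c(-c2ccc(Cl)cc2)c1C(=O)N1CCCCC1=O`: 1820 nM
- compound 3 `CCCCNC(=O)c1c(N)sc(-c2ccc(Cl)cc2)c1-c1ccc(Cl)cc1`: 8170 nM

Compound 3, at 8170 nM, stands level with compound 1 and apart from compound 2. Compound 4 `CC(C)CNC(=O)c1c(N)sc(-c2ccc(Cl)cc2)c1-c1ccc(Cl)cc1` turns butyl into isobutyl on the amide: isopropyl in place of propyl on a saturated chain carbon bound to an amide-type nitrogen. Two measured steps change this same amide substituent: a 1.8-fold higher number from compound 1 to compound 3 (0.25 log units; within the scatter) and a 4.5-fold higher number from compound 2 to compound 3 (0.65 log units; beyond the scatter). Both swap whole groups, and none tests branching of the chain, so only a small change is expected in this assay. The expected step is a 1.2-fold lower number from compound 3 to compound 4 (0.07 log units; within the scatter), with no direction beyond the scatter. Compound 4 is estimated at 7000 nM, with an expected range of 3500 nM to 14000 nM.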

Compound 4, half-maximal inhibitory concentration: 21000 nM
Estimate against measurement, compound 4: 3.0-fold (0.48 log units) below, and the stated range ends below it.
By their numbers in this assay, from the lowest: compound 2; then compounds 1 and 3 (each within the scatter of the next); then compound 4.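

In this assay, moving the same atoms into a branched chain is enough to shift the number: butyl to isobutyl gives a 2.6-fold higher number from compound 3 to compound 4 (0.41 log units; beyond the scatter) at this amide position, so chain shape counts here and not only whole-group swaps. The isobutylamino group also separates from both ring-bearing amides, with a 4.5-fold higher number from compound 1 to compound 4 (0.66 log units; beyond the scatter) for piperidin-1-yl and a 12-fold higher number from compound 2 to compound 4 (1.06 log units; beyond the scatter) for 2-oxopiperidin-1-yl as the starting group. No measurement here offers a reason for the branching effect.

A single branched chain cannot show whether a tert-butyl group or a longer chain such as pentyl would raise the number further or bring it back. On these data alone, how a cyclopropylmethyl group would compare with isobutyl also remains open.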